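Fluoro Removal Tested Against an Assay Ceiling

The source may hold more compounds than are shown below. What is called first, only, known or untested is meant among the compounds shown, and "the series" means these compounds.

Compound 2 `Nc1nc(N)c(CCCNc2cc(F)cc(F)c2[N+](=O)[O-])c(O)n1` carries two fluoro groups, and in a functional assay on CCRF-CEM cells (Homo sapiens) for cytotoxicity, in the presence of a further agent that is not named here (on this read-out lower numbers stand for stronger inhibition and higher numbers for weaker inhibition), compound 2 gives 94000 nM. Compound 1 `Nc1nc(N)c(CCCNc2cc(F)ccc2[N+](=O)[O-])c(O)n1` differs from it by hydrogen in place of fluoro on an aromatic carbon. In this assay compound 1 gives only a limit, > 100000 nM. The measured step is an at least 1.0-fold higher number from compound 2 to compound 1 (0.02 log units; that floor lies within the scatter). Compound 3 `Nc1nc(N)c(CCCN(Cc2ccc(NC(CCC(=O)O)C(=O)O)cc2)c2cc(F)cc(F)c2[N+](=O)[O-])c(O)n1` is the larger analogue; how its core differs from that of compound 2 is not broken down here. In this assay compound 3 gives only a limit, > 100000 nM. Compound 4 `Nc1nc(N)c(CCCN(Cc2ccc(NC(CCC(=O)O)C(=O)O)cc2)c2cc(F)ccc2[N+](=O)[O-])c(O)n1` stands to compound 3 as compound 1 stands to compound 2, the same change, (hydrogen in place of fluoro on an aromatic carbon). Because (the limit of > 100000 nM in this assay, at which 2 of the 3 values shown sit), there is little room for any measurable step, and the expected step is a step that the limit leaves unreadable from compound 3 to compound 4, in keeping with the measured pair. Compound 4 is therefore estimated at 150000 nM, most likely again reported only as a limit.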

Compound 4, half-maximal inhibitory concentration: > 100000 nM
Compound 4: a limit, no number (the forecaster's own chance of this, stated with the estimate: 75%); the middle value lies beyond the limit too.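

No step can be read from compound 3 to compound 4, because both give only a limit: the limit of > 100000 nM in this assay, at which 3 of the 4 values shown sit.

The compounds shown leave open whether hydrogen in place of fluoro changes the result in this assay at all.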